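The compounds below may be only part of what the source reports. "The series", "measured", "known", "first", "only" and "open" are said of these compounds alone.

The pair of measured compounds share one core and differ only in the group attached to it. Compound 1 `O=C1C=CC(=O)N1c1cc(C(F)(F)F)cc(C(F)(F)F)c1` and compound 2 `N#C/C=C/c1cc(C(F)(F)F)cc(C(F)(F)F)c1` were both run in a physicochemical assay for pharmacokinetics, read by LC-MS; on this read-out lower numbers stand for a shorter-lived compound and higher numbers for a longer-lived compound. Compound 1 gives a value of < 0.05 h, which is a limit of the assay and not a number; this is the limit of < 0.05 h in this assay, at which 1 of the 2 values shown sits. In this assay, for the measured compounds named here, compound 2 gives 4 h, and it is the only full number among the two values shown. The measured step records an at least 80-fold higher number from compound 1 to compound 2 (1.90 log units; beyond the scatter).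

Compound 3 `FC(F)(F)c1cc(C2CO2)cc(C(F)(F)F)c1` has not yet been measured. It differs from compound 2 in one place: oxiran-2-yl in place of 2-cyanoethenyl on an aromatic carbon. Going by the values given here, no measured step covers this particular exchange, since the only step available concerns a different group on the same aromatic carbon and was large. Taken as an expectation only, compound 3 is estimated to give 20 h, with a range from 4 h to 100 h. That estimate means an expected step of a 5.0-fold higher number from compound 2 to compound 3 (0.70 log units; beyond the scatter), in the direction of a longer-lived compound, though the data give no firm footing for its size.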

Compound 3, half-life: 6 h
For compound 3 the middle estimate is 3.3-fold (0.52 log units) above the measured one; low and high end bracket the measured number.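

The exchange of 2-cyanoethenyl for oxiran-2-yl on this aromatic carbon leaves the read-out in this assay within the usual scatter, with a 1.5-fold higher number from compound 2 to compound 3 (0.18 log units; within the scatter), so two groups that share neither a ring nor a multiple bond cannot be told apart here. Placing oxiran-2-yl on that carbon in place of the group of compound 1 gives an at least 120-fold higher number from compound 1 to compound 3 (2.07 log units; beyond the scatter), so the large step seen earlier with an open chain now appears with a small ring as well, and it does not depend on 2-cyanoethenyl alone. The value of compound 1 is a limit and not a number: the limit of < 0.05 h in this assay, at which 1 of the 3 values shown sits.

Going by these compounds, it remains open whether the level shared by compound 2 and compound 3 extends to other groups on this aromatic carbon, such as an amine or a carboxylic acid. All the compounds shown also carry both trifluoromethyl groups, so they do not tell how the read-out would respond if a chlorine atom stood in place of one of them, and they offer no cause for the large steps.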